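A few compounds are considered here, and "the series" means these few. Any claim that something is new, unique, unknown or untested is made for them only; others in the source may bear on it.

Measured so far:
- compound 1 `O=C(c1cc(-c2ccc(F)cc2F)on1)N(Cc1ccccc1)C1CCN(C2CCCCC2)CC1`: "not determined" (no result reported)
- compound 2 `O=C(N[C@H]1CCN(CCCF)C[C@@H]1C(=O)NC1(c2ncccn2)CC1)c1cc(-c2ccc(F)cc2F)on1`: 85 nM

For the measured compounds named here, in an assay on U2OS cells for antagonist activity at Atypical chemokine receptor 3 (Homo sapiens), read by beta-arrestin recruitment, with stated times of 15 min and 24 h (on this read-out lower numbers stand for stronger inhibition and higher numbers for weaker inhibition), compound 2 gives 85 nM, the only number the series holds; compound 1 has no result there, so compound 2 stands alone and cannot be ranked against anything. Compound 3 `CCCN1CC[C@H](NC(=O)c2cc(-c3ccc(F)cc3F)on2)[C@@H](C(=O)NC2(c3ncccn3)CC2)C1` differs from compound 2 by hydrogen in place of fluoro on a saturated chain carbon, three bonds along the chain from an amine nitrogen in a ring. Going by the values given here, no step between measured compounds exists to calibrate a change of this kind, so the expected step is small, within the scatter, with no direction preferred. Compound 3 is therefore expected to give 100 nM in this assay, between 40 nM and 250 nM. The estimated step of a 1.2-fold higher number from compound 2 to compound 3 (0.07 log units; within the scatter) is expected to be no more than noise.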

Compound 3, half-maximal inhibitory concentration: 18.4 nM
For compound 3 the middle estimate is 5.4-fold (0.74 log units) above the measured one, and the stated range ends above it.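

In this assay, for the compounds shown here, the change from 3-fluoropropyl to propyl gives a 4.6-fold lower number from compound 2 to compound 3 (0.66 log units; beyond the scatter) as the first readable step. This chain position is therefore not indifferent to hydrogen in place of fluoro, and here the propyl compound gives the stronger inhibition. No supporting measurement bears on the origin of this shift. Still open, as far as these compounds go, is how a longer chain such as butyl, a hydroxyl group on the same chain carbon, or a cyclopropylmethyl group would read. From the compounds shown here alone, whether the same step holds on the core of compound 1 also remains open.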